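Swapping 4-methylphenyl for pyridin-2-yl on the shared core

This account rests on a few compounds, and the source may have more. Where it says the series, first, only, none or still open, it means among the compounds named here.

Of the compounds shown here, three on a shared core have been measured in a functional assay on K562 cells (Homo sapiens) for cytotoxicity, read by ELISA, with a stated time of 4 days; on this read-out lower numbers stand for stronger inhibition and higher numbers for weaker inhibition. Compound 1 (`Clc1ccc(-c2cc(-c3ccoc3)cc(-c3ccco3)n2)s1`) gives 16200 nM, compound 2 (`Cc1ccc(-c2cc(-c3ccoc3)cc(-c3ccc(Cl)s3)n2)o1`) gives 12700 nM and compound 3 (`Cc1ccc(-c2cc(-c3ccoc3)cc(-c3ccc(Cl)s3)n2)cc1`) gives 17900 nM. The number for compound 3 lies within the scatter of both others, so no order can be drawn among the three.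

The next compound, compound 4 (`Clc1ccc(-c2cc(-c3ccoc3)cc(-c3ccccn3)n2)s1`), differs from compound 3 at one place, with pyridin-2-yl in place of 4-methylphenyl on an aromatic carbon.

Among the compounds with values here, two measured steps touch this same place. One is a 1.1-fold higher number from compound 1 to compound 3 (0.04 log units; within the scatter), and the other is a 1.4-fold higher number from compound 2 to compound 3 (0.15 log units; within the scatter). A third, a 1.3-fold lower number from compound 1 to compound 2 (0.11 log units; within the scatter), adds methyl to the furan-2-yl group at that place. All three stay within the scatter, so furan-2-yl, 5-methylfuran-2-yl and 4-methylphenyl cannot be told apart here. Within the data shown here, no measured compound carries pyridin-2-yl at this place, which leaves the new group untested. On these steps, no change beyond the scatter is expected in this assay. The estimated step is a 1.3-fold lower number from compound 3 to compound 4 (0.11 log units; within the scatter). For compound 4 the expected value is 14000 nM, with an estimated range from 6000 nM to 30000 nM.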

Compound 4, half-maximal inhibitory concentration: 20000 nM
For compound 4 the middle estimate is 1.4-fold (0.15 log units) below the measured one, within the range that was stated.
By their numbers in this assay, from the lowest: compounds 2, 1, 3 and 4 (each within the scatter of the next).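

In this assay, the change from a carbon-only six-membered aromatic ring to pyridin-2-yl, which brings a ring nitrogen and a hydrogen-bond acceptor to this place next to the ring nitrogen of the core, gives a 1.1-fold higher number from compound 3 to compound 4 (0.05 log units; within the scatter). Set against the two five-membered groups, pyridin-2-yl gives a 1.6-fold higher number from compound 2 to compound 4 (0.20 log units; within the scatter) and a 1.2-fold higher number from compound 1 to compound 4 (0.09 log units; within the scatter), so all four groups now seen at this place, including the new one with its hetero atom in a six-membered ring, remain within the scatter of one another and cannot be told apart. No supporting measurement bears on this result, so it describes only the size of the steps and offers no explanation for them.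

On these data alone, it remains open whether a group of a different kind at this place, such as an amine or a carboxylic acid, would give a step beyond the scatter. Also open, as far as these compounds go, is how the number responds to changes at the places held by the furan-3-yl and 5-chlorothiophen-2-yl groups, which stay the same in all four compounds.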